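A few compounds are considered here, and "the series" means these few. Any claim that something is new, unique, unknown or untested is made for them only; others in the source may bear on it.

Compound 1 `CNC1=C(Br)C(=O)c2ccncc2C1=O` gives 0.22 ug/mL in a functional assay on IC2 cells (Mus musculus) for cytotoxicity, read by MTT assay, with a stated time of 72 h (a lower number here means a stronger inhibitor, a higher number a weaker inhibitor), the highest of the three numbers recorded so far. Compound 2 `CNC1=CC(=N)c2ccncc2C1=O` gives 0.03 ug/mL in this assay, and compound 3 `CNC1=C/C(=N\CCO)c2ccncc2C1=O` gives 0.1 ug/mL; both lie below compound 1 by gaps beyond the scatter, compound 3 being the nearer and compound 2 the further. Compound 4 `CNC1=C(Cl)C(=O)c2ccncc2C1=O` has not been measured. It differs from compound 1 by chloro in place of bromo on a double-bonded ring carbon. Among the measured compounds shown here, no measured pair shows a change of this kind, so there is no step to lean on. Compound 4 is expected to stay close to its parent, the step of a 1.4-fold higher number from compound 1 to compound 4 (0.13 log units; within the scatter) remaining within the usual scatter. Compound 4 is estimated at 0.3 ug/mL in this assay, with a range from 0.1 ug/mL to 0.9 ug/mL.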

Compound 4, half-maximal inhibitory concentration: 0.28 ug/mL
Beside the measured number, compound 4's estimate is 1.1-fold (0.03 log units) above it, and the stated range covers the measured number.
By their numbers in this assay, from the lowest: compound 2; then compound 3; then compounds 1 and 4 (each within the scatter of the next).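

In this assay, chloro in place of bromo on the double-bonded ring carbon gives a 1.3-fold higher number from compound 1 to compound 4 (0.10 log units; within the scatter), so the two halogens cannot be told apart at this position. Among the compounds shown here, this is the first measured pair that differs in one place, and it gives the first direct reading of this carbon on the shared core. Nothing at hand offers an explanation for this result. From the compounds shown here alone, whether fluoro or iodo would read the same here stays open, and so does the outcome with a methyl group or an amine on this carbon.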